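Replacing 3-chlorophenyl with 4-hydroxyphenyl in compound 1

The compounds below may be only part of what the source reports. "The series", "measured", "known", "first", "only" and "open" are said of these compounds alone.

Going by the values given here, in a functional assay on MCF7 cells (Homo sapiens) for inhibition, read by sulforhodamine B assay (a lower number here means a stronger inhibitor of growth, a higher number a weaker inhibitor of growth), compound 1 `Cc1ccc2[nH]c(-c3ccc(-c4ccc(-c5cccc(Cl)c5)cc4)cc3)nc2c1` gives 1210 nM, the lowest number of the three measured so far. Compound 2 `FC(F)(F)Oc1ccc(-c2ccc(-c3ccc(-c4nc5ccccc5[nH]4)cc3)cc2)cc1` gives 38400 nM and compound 3 `Clc1cccc(-c2ccc(-c3ccc(-c4nc5ccccc5[nH]4)cc3)cc2)c1` gives 36300 nM, two values within the usual scatter of each other. Compound 4 `Cc1ccc2[nH]c(-c3ccc(-c4ccc(-c5ccc(O)cc5)cc4)cc3)nc2c1` has not yet been measured. It keeps the core of compound 1, methyl included, but carries 4-hydroxyphenyl in place of 3-chlorophenyl on an aromatic carbon, para to a large group: 4-hydroxyphenyl in place of 3-chlorophenyl on an aromatic carbon.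

Among the compounds with values here, no measured step makes this exchange. The only one available, a 30-fold higher number from compound 1 to compound 3 (1.48 log units; beyond the scatter), is large, but it concerns hydrogen in place of methyl, a change compound 4 does not make. The closest hint comes from compound 2 at 38400 nM and compound 3 at 36300 nM, which carry different groups yet do not separate in this assay. Neither of them, however, has the methyl or the 4-hydroxyphenyl. A moderate move to a higher number is therefore expected, well short of the loss seen on removing the methyl, though with wide uncertainty. The expected change is a 2.5-fold higher number from compound 1 to compound 4 (0.39 log units; beyond the scatter). For compound 4 the estimate is 3000 nM, with an expected range from 600 nM to 15000 nM.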

Compound 4, concentration for 50% growth inhibition: 12100 nM
Compound 4: middle estimate off by 4.0-fold (0.61 log units), on the low side; the range from low to high includes it.
By their numbers in this assay, from the lowest: compound 1; then compound 4; then compounds 3 and 2 (each within the scatter of the next).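

With the methyl kept in place, this assay now shows that the group on this aromatic carbon, para to a large group, matters on its own: the exchange of 3-chlorophenyl for 4-hydroxyphenyl gives a 10-fold higher number from compound 1 to compound 4 (1.00 log units; beyond the scatter). Going by these compounds alone, until now, the only step that could be read concerned the methyl, so this is the first direct sign that the number also responds to a change in this outer group, and here the change moves it away from the low value of compound 1, even though the entering group has the same ring, carries no net charge and adds a hydrogen-bond donor and a hydrogen-bond acceptor. No measurement available here explains why the number rises.

The step changes both the substituent and its place on the ring, so the compounds shown cannot say whether the loss follows from removing the chlorine, from adding the hydroxyl or from the shift in position. A 4-chlorophenyl or a 3-hydroxyphenyl group on the core of compound 1 would separate these, and a 4-methoxyphenyl or 4-aminophenyl group would show how far the outcome depends on the hydroxyl itself.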